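The compounds below may be only part of what the source reports. "The series", "measured", "known", "first", "only" and "open" are said of these compounds alone.

In a functional assay on MCF7 cells (Homo sapiens) for antiproliferative activity, read by MTT assay (on this read-out lower numbers stand for stronger inhibition and higher numbers for weaker inhibition), compound 1 (`COc1cc2c(Oc3ccc(NC(=O)Nc4ccccc4)cc3)ccnc2cc1OCCCCCCC(=O)NO`) gives 1040 nM, while compound 2 (`COc1cc2c(Oc3ccc(NC(=O)Nc4ccccc4Cl)cc3)ccnc2cc1OCCCCCCC(=O)NO`) gives 2780 nM, the higher of the two numbers. Compound 3 (`COc1cc2c(Oc3ccc(NC(=O)Nc4cccc(C)c4)cc3)ccnc2cc1OCCCCCCC(=O)NO`) is unmeasured and carries 3-methylphenyl in place of 2-chlorophenyl on an amide-type nitrogen. Among the compounds with values here, one measured step bears on this, chloro in place of hydrogen on an aromatic carbon, and it is modest but beyond the scatter: a 2.7-fold higher number from compound 1 to compound 2 (0.43 log units; beyond the scatter). Within the data shown here, compound 3 has no chloro, so a modest step to a lower number is expected, although no measured compound carries 3-methylphenyl. The expected change is a 1.7-fold lower number from compound 2 to compound 3 (0.24 log units; within the scatter). The estimated value for compound 3 is 1600 nM, with a range of 700 nM to 3500 nM.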

Compound 3, half-maximal inhibitory concentration: 1240 nM
Estimate against measurement, compound 3: 1.3-fold (0.11 log units) above; the measured number falls inside the stated range.
By their numbers in this assay, from the lowest: compounds 1 and 3 (each within the scatter of the next); then compound 2.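

In this assay, 3-methylphenyl in place of 2-chlorophenyl on the amide-type nitrogen gives a 2.2-fold lower number from compound 2 to compound 3 (0.35 log units; beyond the scatter), a step beyond the scatter. The step that adds only the methyl is a 1.2-fold higher number from compound 1 to compound 3 (0.08 log units; within the scatter), so this methyl, unlike the chloro of compound 2, leaves the number within the scatter of the phenyl compound. Nothing measured here explains this difference.

The compounds shown leave open whether the group or its place on the ring sets the gap. A 3-chlorophenyl or 2-methylphenyl group on the same nitrogen would separate the two.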